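The source may report more compounds than this note shows. Statements on the series, on what has been measured and on what is new or still open speak of the compounds shown alone.

In a functional assay on the whole organism with Mus musculus as the target (a higher number here means that more compound is needed for the effect, a lower number that less compound is needed), compound 1 `Cc1c(C)c2c(c(C)c1N)CC(C)(C)O2` gives 7.8 mg/kg, compound 2 `CCNc1c(C)c(C)c2c(c1C)CC(C)(C)O2` gives 38.9 mg/kg and compound 3 `CCCNc1c(C)c(C)c2c(c1C)CC(C)(C)O2` gives 51.1 mg/kg. Compound 3 thus sits within the scatter of compound 2, and both lie clearly above compound 1. The next structure, compound 4 `Cc1c(C)c2c(c(C)c1Nc1ccccc1)CC(C)(C)O2`, has phenyl in place of propyl on a nitrogen on an aromatic ring. Adding a group to that nitrogen raised the number, giving a 5.0-fold higher number from compound 1 to compound 2 (0.70 log units; beyond the scatter) and a 6.6-fold higher number from compound 1 to compound 3 (0.82 log units; beyond the scatter). Going from ethyl to propyl gave only a 1.3-fold higher number from compound 2 to compound 3 (0.12 log units; within the scatter), which is within the scatter. As far as these compounds go, compound 4 keeps a group on that nitrogen, but phenyl there is untested, so no step beyond the scatter is expected. The expected step is a 1.1-fold lower number from compound 3 to compound 4 (0.06 log units; within the scatter). Compound 4 is estimated at 45 mg/kg, with an expected range from 15 mg/kg to 130 mg/kg.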

Compound 4, dose for 50% inhibition: > 50 mg/kg
Compound 4: no number, only a limit (the forecaster's own chance of this, stated with the estimate: 10%); middle value at least 1.1-fold (0.04 log units) from the limit.
By their numbers in this assay, from the lowest: compound 1; then compounds 2 and 3 (each within the scatter of the next).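

In this assay compound 4 gives > 50 mg/kg, which is a limit of the assay and not a number. Even so, a ring on this nitrogen, like the ethyl and propyl chains, moves the number away from the free amine, with an at least 6.4-fold higher number from compound 1 to compound 4 (0.80 log units; beyond the scatter), while the floor of an at least 1.2-fold higher number from compound 2 to compound 4 (0.10 log units; that floor lies within the scatter) separates phenyl from ethyl by no more than the scatter. The step between compound 3 and compound 4 cannot be read because of the limit: the limit of > 50 mg/kg in this assay, at which 1 of the 4 values shown sits.

As far as these compounds go, the true distance of phenyl from the propyl chain therefore stays open. Also open, from the compounds shown here alone, is whether a methyl or an acetyl group on this nitrogen would stay close to compound 1.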